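Swapping the aryl amide end for a chloropyridine

The source may hold more compounds than are shown below. What is called first, only, known or untested is meant among the compounds shown, and "the series" means these compounds.

Measured so far:
Compound 1 `NC(=O)/C(=N/O)Nc1ccc(F)c(Cl)c1`: 24000 nM
Compound 2 `O=C(Nc1ccc(Cl)cc1)C(=O)N1CCC(c2ccnc3ccc(F)cc23)CC1`: 15 nM
Compound 3 `N#Cc1ccc(NC(=O)C(=O)N2CCC(c3ccnc4ccc(F)cc34)CC2)cc1`: 36 nM

In an assay on SK-OV-3 cells for inhibition of Indoleamine 2,3-dioxygenase 1 (Homo sapiens) (a higher number here means a weaker inhibitor, a lower number a stronger inhibitor), compound 3 gives 36 nM, the second highest of the three numbers. Its nearest neighbour is compound 2 with 15 nM; the small open-chain compound 1 stands far away at 24000 nM. Within the data shown here, the one step that has been measured between close relatives is a 2.4-fold higher number from compound 2 to compound 3 (0.38 log units; beyond the scatter), so replacing chloro by cyano on the aryl ring cost some potency.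

Compound 4 `O=C(Nc1ccc(Cl)cn1)C(=O)N1CCC(c2ccnc3ccc(F)cc23)CC1` is not yet measured. It differs from compound 3 in one place: 5-chloropyridin-2-yl in place of 4-cyanophenyl on an amide-type nitrogen. The change brings chloro back, which is exactly what the step from compound 2 to compound 3 speaks to, and at the same time puts a nitrogen into the six-membered aromatic ring, a change for which no comparison exists here. If the return of chloro behaves as before, the number should move back toward that of compound 2; the ring nitrogen is an unknown and widens the range. The expected step is therefore a 1.6-fold lower number from compound 3 to compound 4 (0.21 log units; within the scatter), a modestly lower number. For compound 4 the estimate in this assay is 22 nM, with a range from 8 nM to 70 nM.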

Compound 4, half-maximal inhibitory concentration: 70 nM
Estimate against measurement, compound 4: 3.2-fold (0.50 log units) below; the measured number falls inside the stated range.
By their numbers in this assay, from the lowest: compound 2; then compounds 3 and 4 (each within the scatter of the next); then compound 1.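

In this assay, among these compounds, the change from 4-chlorophenyl to 5-chloropyridin-2-yl on the amide-type nitrogen keeps the chloro and adds a nitrogen to the ring, and it gives a 4.7-fold higher number from compound 2 to compound 4 (0.67 log units; beyond the scatter) as the first reading of a ring nitrogen at this place. A chloro on the ring therefore does not by itself carry the low number of compound 2, since the ring made of carbon only also matters for this pair, while the other step, a 1.9-fold higher number from compound 3 to compound 4 (0.29 log units; within the scatter), leaves 5-chloropyridin-2-yl and 4-cyanophenyl impossible to tell apart in this assay. Nothing measured here explains why the ring nitrogen has this effect.

The compounds shown leave open how a nitrile would read on the pyridine ring, which would separate the choice of ring from the choice of group on it. They also leave open whether a methoxy group or an amine in place of the chloro on that ring, or a methyl group in place of the amide hydrogen, would keep the number near that of compound 2.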